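Swapping the Dichlorophenyl Arm for a Fluorophenyl Arm

The source may hold more compounds than are shown below. What is called first, only, known or untested is meant among the compounds shown, and "the series" means these compounds.

Compound 1 `CC1(C)Cc2c(ccc(C(=O)/C=C/c3ccc(Cl)cc3Cl)c2OCc2ccccc2)O1` was tested in a functional assay on NCI-H460 cells (Homo sapiens) for antiproliferative activity, read by MTT assay, with a stated time of 48 h; a higher number here means a weaker inhibitor, a lower number a stronger inhibitor. In this assay compound 1 reaches only a limit, > 100000 nM. Compound 2 `CC1(C)Cc2c(ccc(C(=O)/C=C/c3cn(-c4ccccc4)nc3-c3ccc(Cl)cc3)c2OCc2ccccc2)O1` likewise gives only a limit in this assay, > 100000 nM. Compound 3 `COc1ccc(/C=C/C(=O)c2ccc(OCc3ccccc3)c3c2OC(C)(C)C3)cc1` also returns a limit in this assay, > 100000 nM. So compound 1 stands nowhere apart from the others: every value so far sits at the limit of > 100000 nM in this assay, at which 3 of the 3 values shown sit, and no real number separates the three.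

Compound 4 `CC1(C)Cc2c(ccc(C(=O)/C=C/c3ccc(F)cc3)c2OCc2ccccc2)O1` differs from compound 1 in one place: 4-fluorophenyl in place of 2,4-dichlorophenyl on a double-bonded chain carbon bound to a double-bonded chain carbon. Among the compounds with values here, with all three measured compounds sitting at the limit, there is no measured step to say how such a change moves this read-out, and the expected step that the limit leaves unreadable from compound 1 to compound 4 is none beyond the scatter. Compound 4 is therefore expected to come in at about 150000 nM, most likely again as a limit, with a range from 40000 nM to 500000 nM.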

Compound 4, half-maximal inhibitory concentration: 75800 nM
Compound 4: the middle estimate sits 2.0-fold (0.30 log units) above what was measured; the range from low to high includes it.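

Within the data shown here, at this place on the chain, the 4-fluorophenyl group gives the first real number in this assay, which shows that a reading within the range of the assay is possible for this series. Yet the gap is an at least 1.3-fold lower number from compound 1 to compound 4 (0.12 log units; that floor lies within the scatter), and compound 1 has only a limit, so the true size of the change stays unknown. Most of the set still gives no number: the limit of > 100000 nM in this assay, at which 3 of the 4 values shown sit.

As far as these compounds go, it remains open whether the fluorine or the loss of the two chlorines matters more. From the compounds shown here alone, it is also open whether an amine on this phenyl ring would lower the number further.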